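The source may report more compounds than this note shows. Statements on the series, on what has been measured and on what is new or still open speak of the compounds shown alone.

Of the compounds shown here, three sharing one core have been measured in a functional assay (aorta) with Rattus norvegicus as the target; a higher number here means a weaker inhibitor, a lower number a stronger inhibitor. Compound 1 (`CC(C)c1cn2ccccc2c1S(=O)(=O)c1ccc(OCCCN2CCC(c3ccccc3)CC2)cc1`) gives 80.9 nM and compound 2 (`CCCCCN(CCCCC)CCCOc1ccc(S(=O)(=O)c2c(C(C)C)cn3ccccc23)cc1`) gives 89.6 nM, and the comparison shows a 1.1-fold higher number from compound 1 to compound 2 (0.04 log units; within the scatter). Compound 3 (`CCCCN(CCCC)CCCOc1ccc(S(=O)(=O)c2c(C(C)C)cn3ccccc23)cc1`) gives 21.6 nM, the lowest of the three numbers, which makes it the strongest inhibitor so far. The measurements show a 3.7-fold lower number from compound 1 to compound 3 (0.57 log units; beyond the scatter) and a 4.1-fold lower number from compound 2 to compound 3 (0.62 log units; beyond the scatter).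

Compound 4 (`CCCCN(CCCC)CCCOc1ccc(S(=O)(=O)c2c(C3CCCCC3)cn3ccccc23)cc1`) keeps the dibutylamino group of compound 3 and carries cyclohexyl in place of isopropyl on an aromatic carbon. All three measured steps swap the group on the saturated chain carbon, and none touches this aromatic carbon, so no measurement speaks directly to the new change. The steps show only how far a single change elsewhere in these molecules has moved the number, and both steps that involve compound 3 are modest. With compound 3 at the low end of what has been seen, a small move toward a higher number seems more likely than a further drop. The expected step is a 1.4-fold higher number from compound 3 to compound 4 (0.14 log units; within the scatter), a loose estimate. For compound 4 the estimated value is 30 nM, with an expected range from 8 nM to 110 nM.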

Compound 4, half-maximal inhibitory concentration: 4070 nM
Beside the measured number, compound 4's estimate is 140-fold (2.13 log units) below it; measured number above the stated range.
By their numbers in this assay, from the lowest: compound 3; then compounds 1 and 2 (each within the scatter of the next); then compound 4.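

In this assay, this aromatic carbon, two ring bonds from the ring nitrogen, proves far more sensitive to change than the saturated chain carbon: cyclohexyl in place of isopropyl gives a 190-fold higher number from compound 3 to compound 4 (2.28 log units; beyond the scatter), while the largest step seen at the chain carbon is a 4.1-fold lower number from compound 2 to compound 3 (0.62 log units; beyond the scatter). The swap replaces isopropyl, with 3 heavy atoms and no ring, by cyclohexyl, with 6 heavy atoms and a six-membered non-aromatic ring of carbon only, and neither group has hydrogen-bond donors or acceptors, so a change made of carbon alone is enough for this large loss. No measurement here gives a reason for the loss.

The compounds shown leave open whether the ring itself or the larger number of carbons matters: cyclopropyl, a ring, and tert-butyl, an open-chain group, at this aromatic carbon would help separate the two. Among these compounds, also open is whether cyclohexyl has the same effect alongside dipentylamino or 4-phenylpiperidin-1-yl, as the only pair compared at this carbon carries dibutylamino.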